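The compounds below may be only part of what the source reports. "The series", "measured", "known", "first", "only" and "open" are said of these compounds alone.

Compound 1 `COc1cc(OC)c2sc(-c3ccc(N/C=C\C(=O)c4ccc(OC)c([N+](=O)[O-])c4)c(C)c3)nc2c1`, compound 2 `COc1cc(OC)c2sc(-c3ccc(N/C=C\C(=O)c4ccc(OC)c(O)c4)cc3)nc2c1` and compound 3 `COc1ccc(C(=O)/C=C\Nc2ccc(-c3nc4cc(OC)c(OC)c(OC)c4s3)cc2)cc1O` have been measured, while compound 4 `COc1cc(OC)c2sc(-c3ccc(N/C=C\C(=O)c4cc(OC)c(OC)c([N+](=O)[O-])c4)c(C)c3)nc2c1` has not. In a functional assay on A549 cells (Homo sapiens) for antiproliferative activity, read by sulforhodamine B assay, with a stated time of 48 h (on this read-out lower numbers stand for stronger inhibition and higher numbers for weaker inhibition), compound 1 gives 12100 nM, compound 2 gives 10600 nM and compound 3 gives 23000 nM. The difference between the cores of compound 1 and compound 2 is not broken down here. Compound 3 arises from compound 2 by methoxy in place of hydrogen on an aromatic carbon, a step that made a 2.2-fold higher number from compound 2 to compound 3 (0.34 log units; beyond the scatter). Compound 4 arises from compound 1 by the same kind of change, (methoxy in place of hydrogen on an aromatic carbon), though the place is not the same: in compound 3 the new group sits ortho to two methoxy groups, meta to a fused ring and para to a fused ring, whereas in compound 4 it sits ortho to a methoxy group, meta to a large group and meta to a nitro group. Resting on that one earlier step in this assay, a shift of a 1.7-fold higher number from compound 1 to compound 4 (0.24 log units; within the scatter) is expected. Compound 4 is therefore estimated at 21000 nM, likely between 9000 nM and 50000 nM.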

Compound 4, half-maximal inhibitory concentration: 15400 nM
Estimate against measurement, compound 4: 1.4-fold (0.13 log units) above; the measured number falls inside the stated range.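

In this assay, methoxy in place of hydrogen on the aromatic ring of compound 1 gives a 1.3-fold higher number from compound 1 to compound 4 (0.10 log units; within the scatter). Set beside the same change on the other core, the two steps cannot be told apart: the same change on two cores in this assay, a 2.2-fold higher number (0.34 log units; beyond the scatter) from compound 2 to compound 3 and a 1.3-fold higher number (0.10 log units; within the scatter) from compound 1 to compound 4, 1.7-fold (0.23 log units) apart, within the scatter of two such steps. Among these compounds, this fits a change that carries across these two cores with a broadly similar result, but it rests on only two pairs, the new group sits in a different place in each, and only one of the two steps lies beyond the scatter, so it shows no general rule.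

The compounds shown leave open what a group other than methoxy, such as an ethoxy or an amine, would do at this place. They also leave open how the change would behave on any further core.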